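Changing the benzyl ring substituent in a benzimidazole nucleoside series

The compounds below may be only part of what the source reports. "The series", "measured", "known", "first", "only" and "open" are said of these compounds alone.

Of the compounds shown here, two sharing one core have been measured in a functional assay on KB cells (Homo sapiens) for inhibition; on this read-out lower numbers stand for stronger inhibition and higher numbers for weaker inhibition. Compound 1 `OC[C@H]1OC(n2c(SCc3ccc(Br)cc3)nc3cc(Cl)c(Cl)cc32)[C@H](O)[C@@H]1O` gives 20000 nM in this assay. Compound 2 `OC[C@H]1OC(n2c(SCc3ccccc3Cl)nc3cc(Cl)c(Cl)cc32)[C@H](O)[C@@H]1O` gives 30000 nM in this assay, the highest of the two numbers, though the step of a 1.5-fold higher number from compound 1 to compound 2 (0.18 log units; within the scatter) lies within the scatter. Compound 3 `Cc1cccc(CSc2nc3cc(Cl)c(Cl)cc3n2C2O[C@H](CO)[C@@H](O)[C@H]2O)c1` has not yet been measured. It differs from compound 2 by 3-methylphenyl in place of 2-chlorophenyl on a saturated chain carbon bound to a sulfur. For the measured compounds named here, only one measured step bears on this change, the step of a 1.5-fold higher number from compound 1 to compound 2 (0.18 log units; within the scatter), which swapped one substituted phenyl for another at the same place and stayed within the scatter. A further swap of this kind, to 3-methylphenyl, is therefore expected to give no step beyond the scatter in this assay. The step of a 1.2-fold lower number from compound 2 to compound 3 (0.08 log units; within the scatter) is the estimated outcome. Compound 3 is expected to give about 25000 nM in this assay, with a range from 10000 nM to 60000 nM.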

Compound 3, half-maximal inhibitory concentration: 30000 nM
Estimate against measurement, compound 3: 1.2-fold (0.08 log units) below; measured number inside the range.
By their numbers in this assay, from the lowest: compounds 1, 2 and 3 (each within the scatter of the next).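

In this assay, exchanging 2-chlorophenyl for 3-methylphenyl on a saturated chain carbon bound to a sulfur gives no change at the digits printed from compound 2 to compound 3 (within the scatter), and exchanging 4-bromophenyl for it gives a 1.5-fold higher number from compound 1 to compound 3 (0.18 log units; within the scatter). Compound 3 is the first of these compounds whose phenyl ring carries carbon alone and no halogen, so among compounds 1, 2 and 3 a halogen on this ring makes no difference beyond the scatter. Nothing available explains why these changes leave the read-out within the scatter.

The compounds shown leave open whether an amine or a carboxylic acid on the phenyl ring would give a step beyond the scatter. They also do not show what a longer chain between the sulfur and the ring would do.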